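The source may report more compounds than this note shows. Statements on the series, on what has been measured and on what is new or still open speak of the compounds shown alone.

Working notes on the series. In an ADME assay on L929 cells (Mus musculus) for cytotoxicity, read by resazurin assay, with a stated time of 96 h (a lower number here means that less compound is tolerated, a higher number that more compound is tolerated), compound 1 `NC(=S)N/N=C(/COc1ccc(Br)cc1)c1ccccc1` gives < 27500 nM, which is a limit and not a number. Among the measured compounds shown here, compound 2 `Cc1ccc(/C(COc2ccc(Br)cc2)=N\NC(N)=S)cc1` gives 13200 nM, the only number so far in this assay. For the measured compounds named here, the one measured step, a step that the limit leaves unreadable from compound 1 to compound 2, is methyl in place of hydrogen on an aromatic carbon, and it offers no size to carry forward. Compound 3 `COc1ccc(/C(COc2ccc(Br)cc2)=N\NC(N)=S)cc1` differs from compound 2 by methoxy in place of methyl on an aromatic carbon, para to a large group. Going by the values given here, no measured step bears on this exchange, so no direction can be argued, and the expectation rests on compound 2 at 13200 nM. The expected change is a 1.0-fold lower number from compound 2 to compound 3 (0.01 log units; within the scatter), with nothing expected beyond the scatter in this assay. For compound 3 the estimated value is 13000 nM, with an expected range of 6000 nM to 27000 nM.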

Compound 3, half-maximal cytotoxic concentration: < 25400 nM
Compound 3: only a limit was reported; the forecaster's own chance of this, stated with the estimate: 15%; the middle value is on the limit's open side.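

In this assay compound 3 gives < 25400 nM, a limit and not a number, so the steps to compound 3 from compound 2 and from compound 1 cannot be read. The compounds shown leave open whether methoxy in place of methyl changes the number at all.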